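Swapping 2-chlorophenyl for 4-chlorophenyl in compound 1

The source may report more compounds than this note shows. Statements on the series, on what has been measured and on what is new or still open speak of the compounds shown alone.

Values measured so far in a physicochemical assay for lipophilicity (a lower number here means a more polar compound, a higher number a more lipophilic compound), are as follows
- Compound 1 `CCOC(=O)C1=C(C)NC(=S)NC1c1cn(C(=O)CNc2ccccc2Cl)c2ccccc12` gives 3.44
- Compound 2 `CCOC(=O)C1=C(C)NC(=O)NC1c1cn(C(=O)CNc2ccccc2[N+](=O)[O-])c2ccccc12` gives 1.48
- Compound 3 `CCOC(=O)C1=C(C)NC(=O)NC1c1cn(C(=O)CNc2ccc([N+](=O)[O-])cc2)c2ccccc12` gives 1.48

Compound 1 holds the highest number of the three and stands beyond the scatter above both compound 2 and compound 3. Compound 4 `CCOC(=O)C1=C(C)NC(=S)NC1c1cn(C(=O)CNc2ccc(Cl)cc2)c2ccccc12` has not yet been measured. It carries 4-chlorophenyl in place of 2-chlorophenyl on an amine nitrogen and is otherwise the same as compound 1.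

Among the compounds with values here, one measured step bears on this swap. Within the data shown here, with 4-nitrophenyl in place of 2-nitrophenyl on an amine nitrogen, the outcome was no change at the digits printed from compound 2 to compound 3 (within the scatter) in this assay and that is the only such pair available. Among the measured compounds shown here, no pair with chlorophenyl groups has been measured, so this precedent is indirect. On that basis, the expected outcome is no change at the digits printed from compound 1 to compound 4 (within the scatter) with no direction favoured. Compound 4 is expected at 3.44 with an estimated range from 3.1 to 3.8 around it.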

Compound 4, partition coefficient: 3.44
Compound 4: the middle estimate sits on the measured number at the digits printed; the measured number falls inside the stated range.
By their numbers in this assay, from the lowest: compounds 2 and 3 (each within the scatter of the next); then compounds 1 and 4 (each within the scatter of the next).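

In this assay, putting 4-chlorophenyl in place of 2-chlorophenyl on an amine nitrogen gives a clear result (no change at the digits printed from compound 1 to compound 4 (within the scatter)). The only earlier case of this kind of swap used nitrophenyl groups (no change at the digits printed from compound 2 to compound 3 (within the scatter)), so there are now two pairs, with two different groups on the phenyl ring, in which the 2-substituted and 4-substituted forms give the same number at the digits printed. Nothing available explains why these swaps leave the number in place.

Going by these compounds, two pairs cannot show how far this holds, so it remains open whether the same would be seen with a carboxylic acid or a methoxy group on that phenyl ring. On these data alone, it is equally open what a longer chain between the amine nitrogen and the carbonyl would do to the number.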